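Amine-guanidine ureas at the histamine H2 receptor: partial agonism

The source may hold more compounds than are shown below. What is called first, only, known or untested is meant among the compounds shown, and "the series" means these compounds.

Working notes on a small set of acylguanidines tested in a functional assay on HEK293T cells for agonist activity at histamine H2 receptor (Homo sapiens), read by beta-arrestin recruitment; on this read-out lower numbers stand for smaller maximal responses and higher numbers for larger maximal responses. Among the compounds with values here, compound 1 `Cc1nc(N)sc1CCCN/C(N)=N/C(=O)N[C@H](C)c1ccccc1` gives 0.34 and stands highest of the three numbers so far, though only just: compound 2 `N/C(=N\C(=O)NCc1ccccc1)NC1CCc2nc(N)sc2C1` gives 0.31, a gap within the usual scatter, so no order between compound 1 and compound 2 can be read from these two values. Compound 3 `Cc1nc(N)sc1CCCN/C(N)=N/C(=S)N[C@H](C)c1ccccc1` gives 0.11, which is clearly lower than compound 1, beyond the scatter. Within the data shown here, compound 3 carries a thiourea where compound 1 carries a urea; no single-point step between measured compounds is on record, so this is only what the two values show.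

Compound 4 `Cc1nc(N)sc1CCCN/C(N)=N/C(=O)NCc1ccccc1` has not yet been measured. It differs from compound 1 by one change: hydrogen in place of methyl on a saturated chain carbon bound to an amide-type nitrogen and an aromatic carbon. Compound 2, which also carries a benzyl urea though on a different core, sits within the scatter of compound 1, which gives some ground to expect little movement here. The step from compound 1 to compound 4 is therefore expected to be small, if anything slightly downward, a number 0.040 lower from compound 1 to compound 4 (within the scatter), likely within the scatter. For compound 4 the expected value in this assay is 0.3, with a range from 0.18 to 0.42.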

Compound 4, intrinsic activity: the largest response reached, as a fraction of the reference agonist's: 0.33
For compound 4 the middle estimate is 0.030 below the measured one; the measured number falls inside the stated range.
By their numbers in this assay, from the lowest: compound 3; then compounds 2, 4 and 1 (each within the scatter of the next).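

Within the data shown here, this is the first single-place step: with hydrogen in place of methyl on the saturated chain carbon bound to an amide-type nitrogen and an aromatic carbon, this assay gives a number 0.010 lower from compound 1 to compound 4 (within the scatter). The 1-phenylethyl and benzyl groups therefore cannot be told apart at this position on this read-out, and the methyl, together with the stereocentre it creates, is not needed to keep the maximal response at the level seen for compound 1. No supporting data bear on why this position tolerates the change, so the finding remains a plain observation of two values.

The compounds shown leave open whether this carbon would tolerate anything larger or more functionalised than methyl, such as an ethyl, a hydroxymethyl or a carboxylic acid group, since hydrogen and methyl cover only a narrow part of what could sit there. Also open, on these data alone, is whether the same 1-phenylethyl to benzyl change would leave the response equally unmoved on the thiourea of compound 3.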